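One change on the carbon double-bonded to nitrogen

A few compounds are considered here, and "the series" means these few. Any claim that something is new, unique, unknown or untested is made for them only; others in the source may bear on it.

In a functional assay on SF-539 cells (Homo sapiens) for inhibition, read by sulforhodamine B assay, with a stated time of 48 h (a higher number here means that more compound is tolerated, a lower number that less compound is tolerated), two compounds have been measured:
compound 1, `NS(=O)(=O)c1ccc(Nc2nc(N/N=C/c3ccc(C(F)(F)F)cc3)nc(Nc3ccccc3)n2)cc1`, 9610 nM
compound 2, `Cc1nn(-c2ccccc2)cc1/C=N/Nc1nc(Nc2ccccc2)nc(Nc2ccc(S(N)(=O)=O)cc2)n1`, 6250 nM

On the numbers shown, compound 2 sits at the low end of the pair, yet the step of a 1.5-fold lower number from compound 1 to compound 2 (0.19 log units; within the scatter) is within the scatter, so no real difference between the two compounds is established. Compound 3, `NS(=O)(=O)c1ccc(Nc2nc(N/N=C/c3ccccn3)nc(Nc3ccccc3)n2)cc1`, is not yet measured. It differs from compound 2 in one place: pyridin-2-yl in place of 3-methyl-1-phenyl-1H-pyrazol-4-yl on a carbon with a double bond to nitrogen. Going by the values given here, the only measured step, from compound 1 to compound 2, swapped the group at this same carbon and stayed within the scatter, which is the sole guide available; nothing else bears on the change. A step beyond the scatter is therefore not expected, and the estimated step is a 1.3-fold higher number from compound 2 to compound 3 (0.11 log units; within the scatter). For compound 3 the expected value is 8000 nM, with a range from 2500 nM to 25000 nM.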

Compound 3, concentration lethal to 50% of the cells: 8000 nM
For compound 3 middle estimate and measured number coincide at the digits printed, within the range that was stated.
By their numbers in this assay, from the lowest: compounds 2, 3 and 1 (each within the scatter of the next).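

Putting pyridin-2-yl on the carbon with a double bond to nitrogen gives a 1.3-fold higher number from compound 2 to compound 3 (0.11 log units; within the scatter), and the comparison with the other earlier group gives a 1.2-fold lower number from compound 1 to compound 3 (0.08 log units; within the scatter). In this assay, all three groups at this place therefore stay within the scatter of one another, even though pyridin-2-yl has one ring and 6 heavy atoms, while 3-methyl-1-phenyl-1H-pyrazol-4-yl has two rings and 12 heavy atoms. Nothing available explains why these groups give such similar numbers.

As far as these compounds go, every group seen here at this place is an aromatic ring, so it remains open whether an amine, a carboxylic acid or a longer alkyl chain would give a step beyond the scatter. The shared core is also identical in all three compounds, leaving the effect of a change elsewhere unknown.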